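The source may hold more compounds than are shown below. What is called first, only, known or untested is meant among the compounds shown, and "the series" means these compounds.

For the measured compounds named here, compound 2 `Cc1cc(C)cc(S(=O)(=O)c2c(C(=O)NC(C)C(=O)NCc3ccncc3)[nH]c3ccc(Cl)cc23)c1` is the one member of the set that gives an outright number in an ADME assay on MT4 cells (Homo sapiens) for cytotoxicity, read by MTT assay; a lower number here means that less compound is tolerated, a higher number that more compound is tolerated: compound 2 gives 19500 nM. Compound 1 `Cc1cc(C)cc(S(=O)(=O)c2c(C(=O)NCC(=O)NCc3ccco3)[nH]c3ccc(Cl)cc23)c1` returns only a limit there, > 50000 nM. Compound 3 `Cc1cc(C)cc(S(=O)(=O)c2c(C(=O)NCC(=O)NCc3ccncn3)[nH]c3ccc(Cl)cc23)c1` also returns only a limit, > 48800 nM. The two measured steps that change the group on the amide nitrogen are an at least 2.5-fold lower number from compound 1 to compound 2 (0.40 log units; beyond the scatter) and an at least 2.5-fold higher number from compound 2 to compound 3 (0.39 log units; beyond the scatter); each sits against a limit, as the limit of > 50000 nM in this assay, at which 1 of the 3 values shown sits, and the limit of > 48800 nM in this assay, at which 1 of the 3 values shown sits, show. Compound 4 `Cc1cc(C)cc(S(=O)(=O)c2c(C(=O)NC(C)C(=O)NC(C)c3ccccc3)[nH]c3ccc(Cl)cc23)c1` carries 1-phenylethyl in place of (pyridin-4-yl)methyl on an amide-type nitrogen. Both recorded changes at this position moved upward from the number of compound 2, 19500 nM. A higher number is therefore expected for compound 4, a 1.6-fold higher number from compound 2 to compound 4 (0.22 log units; within the scatter). The estimate for compound 4 is 32000 nM, within a range from 12000 nM to 60000 nM.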

Compound 4, half-maximal cytotoxic concentration: 21700 nM
For compound 4 the middle estimate is 1.5-fold (0.17 log units) above the measured one, within the range that was stated.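

Putting 1-phenylethyl in place of (pyridin-4-yl)methyl on the amide-type nitrogen gives a 1.1-fold higher number from compound 2 to compound 4 (0.05 log units; within the scatter) in this assay. For the compounds shown here, this is the first step at this position with an outright number at both ends, and going from a ring with one hetero atom to a ring of carbon only leaves no readable mark. Nothing at hand gives a cause for this result.

As far as these compounds go, whether an amine, a carboxylic acid or a longer chain in place of 1-phenylethyl would give a number apart from those of compound 2 and compound 4 stays open. Going by these compounds alone, compound 1 and compound 3 return only limits, and no step to compound 4 can be read from them.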